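A few compounds are considered here, and "the series" means these few. Any claim that something is new, unique, unknown or untested is made for them only; others in the source may bear on it.

In a functional assay on A-375 cells (Homo sapiens) for cytotoxicity, read by MTT assay, with a stated time of 48 h (a lower number here means a stronger inhibitor, a higher number a weaker inhibitor), three compounds sharing one core have been measured. Compound 2 `CC1(C)S[C@@H]2/C(=C\C(=O)c3ccc([N+](=O)[O-])cc3)C(=O)N2[C@H]1C(=O)OC(c1ccccc1)c1ccccc1` gives 50300 nM, the lowest of the two numbers obtained in this assay. Compound 3 `CC1(C)[C@H](C(=O)OC(c2ccccc2)c2ccccc2)N2C(=O)/C(=C/C(=O)c3ccc([N+](=O)[O-])cc3)[C@H]2S1(=O)=O` gives 76700 nM in this assay, a value that sits within the usual scatter of the value of compound 2, so the two cannot be placed in order. Compound 1 `CC1(C)S[C@@H]2C/C(=C\C(=O)c3ccccc3)C(=O)N2[C@H]1C(=O)OC(c1ccccc1)c1ccccc1` returns only a limit in this assay, > 100000 nM. That limit is the one recorded as the limit of > 100000 nM in this assay, at which 1 of the 3 values shown sits.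

Compound 4 `COC(=O)/C=C1/C(=O)N2[C@@H]1SC(C)(C)[C@@H]2C(=O)OC(c1ccccc1)c1ccccc1` has not yet been measured in this assay. It differs from compound 2 in one place: methoxy in place of 4-nitrophenyl on a carbonyl carbon. Among the measured compounds shown here, no pair of measured compounds shares this change, so there is no measured step against which the expectation can be scaled. The author expects compound 4 to come out weaker than compound 2 or at best unchanged, with the step of a 1.7-fold higher number from compound 2 to compound 4 (0.23 log units; within the scatter) expected to lie near or just beyond the scatter. Compound 4 is therefore estimated at 85000 nM, with a range from 35000 nM to 200000 nM.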

Compound 4, half-maximal inhibitory concentration: 24600 nM
Beside the measured number, compound 4's estimate is 3.5-fold (0.54 log units) above it; the measured number lies below the stated range.
By their numbers in this assay, from the lowest: compound 4; then compounds 2 and 3 (each within the scatter of the next). At a limit, above all of these: compound 1.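

In this assay, among the compounds shown here, the carbonyl carbon whose other neighbour is the double-bonded chain carbon need not carry 4-nitrophenyl, as the earlier compounds could not show. Replacing that group with methoxy, which turns (4-nitrophenyl)carbonyl into methoxycarbonyl, gives a 2.0-fold lower number from compound 2 to compound 4 (0.31 log units; beyond the scatter), so the smaller group without a ring does not cost activity here and brings a modest gain. Nothing measured here gives a reason for this step.

As far as these compounds go, this rests on a single pair, so it remains open whether the same change would carry over to the core of compound 3. From the compounds shown here alone, it also remains open how an ethoxy group, an amine forming an amide, or a carboxylic acid would compare with methoxy on this carbonyl carbon.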